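A few compounds are considered here, and "the series" means these few. Any claim that something is new, unique, unknown or untested is made for them only; others in the source may bear on it.

Measured compounds:
Compound 1 `O=C(N/N=C/c1ccc([N+](=O)[O-])cc1)Nc1ccc(Oc2ccnc3[nH]ccc23)c(F)c1`: in a functional assay on A549 cells (Homo sapiens) for antiproliferative activity, read by MTT assay, with a stated time of 72 h (a higher number here means a weaker inhibitor, a lower number a stronger inhibitor), compound 1 gives 20 nM.
Compound 2 `COc1ccc(/C=N/NC(=O)Nc2ccc(Oc3ccnc4[nH]ccc34)cc2)c(OC)c1OC`: in this assay compound 2 gives 3340 nM.

Compound 1 holds the lowest number of the two, and the gap to compound 2 lies beyond the usual scatter. Compound 3 `CN(C)CCn1cccc1/C=N/NC(=O)Nc1ccc(Oc2ccnc3[nH]ccc23)c(F)c1` differs from compound 1 in one place: 1-(2-(dimethylamino)ethyl)-1H-pyrrol-2-yl in place of 4-nitrophenyl on a carbon with a double bond to nitrogen. Among the measured compounds shown here, no step between measured compounds that differ in one place is available, so the change is judged only from the two values. The step of a 7.5-fold higher number from compound 1 to compound 3 (0.88 log units; beyond the scatter) is expected to be a loss, moderate in size. Compound 3 is expected to give about 150 nM, in the range 30 nM to 1500 nM.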

Compound 3, half-maximal inhibitory concentration: "not active" (no number reported)
For compound 3 the study gives words and no number; no gap can be computed for the estimate.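

Among the compounds shown here, compound 3 is reported only as not active, with no number, so no step from compound 1 to compound 3 can be read, and no evidence bears on this result. The compounds shown leave open what any single change to the 4-nitrophenyl group does to activity.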